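The source may hold more compounds than are shown below. What is called first, only, known or untested is meant among the compounds shown, and "the series" means these compounds.

Measured so far:
compound 1, `CCOC(=O)[C@@H]1CCCN(S(=O)(=O)c2ccc(S(=N)(=O)N(CC)CC)cc2)C1`, gives 2600 nM
compound 2, `CCN(CC)S(=O)(=O)c1ccc(S(=O)(=O)N2CCC[C@@H](C(=O)NC3CN(S(C)(=O)=O)C3)C2)cc1`, gives 2500 nM

Both numbers come from a functional assay on MIA PaCa-2 cells (Homo sapiens) for inhibition, read by MTT assay, with a stated time of 7 days; a lower number here means a stronger inhibitor, a higher number a weaker inhibitor. Compound 2 has the lower of the two numbers, but only by a hair: its value and that of compound 1 sit within the scatter of each other, so neither can be called stronger than the other. Compound 3, `CCN1CC(NC(=O)[C@@H]2CCCN(S(=O)(=O)c3ccc(S(=O)(=O)N(CC)CC)cc3)C2)C1`, has not yet been measured. It differs from compound 2 in one place, (ethyl in place of methylsulfonyl on an amine nitrogen in a ring), a swap on the nitrogen of the small four-membered ring at the end of the amide. For the measured compounds named here, no measured pair shows how such a swap plays out here, so there is no step to lean on. The step of no change at the digits printed from compound 2 to compound 3 (within the scatter) is therefore expected to stay within the scatter, in no set direction. Compound 3 is expected to give about 2500 nM, most likely between 900 nM and 7000 nM.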

Compound 3, half-maximal inhibitory concentration: > 30000 nM
Compound 3: no number, only a limit (the forecaster's own chance of this, stated with the estimate: 5%); at least 12-fold (1.07 log units) between middle value and limit.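

Compound 1 and compound 2 said nothing about the nitrogen of the four-membered ring, since they do not differ there in one place alone. Putting ethyl in place of methylsulfonyl on this amine nitrogen gives an at least 12-fold higher number from compound 2 to compound 3 (1.07 log units; beyond the scatter), so in this assay the group carried at this position clearly matters. For compound 3 the value > 30000 nM is a limit of the assay, not a number: the limit of > 30000 nM in this assay, at which 1 of the 3 values shown sits.

Still open, going by these compounds, is whether methylsulfonyl is specifically needed at this nitrogen or whether ethyl is simply one poor choice among many. A free amine, an acetyl group or a longer sulfonyl chain such as ethylsulfonyl at the same place would help separate these two readings.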